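The compounds below may be only part of what the source reports. "The series", "measured", "known", "first", "only" and "open" are said of these compounds alone.

In a functional assay on OVCAR-3 cells (Homo sapiens) for cytotoxicity, read by sulforhodamine B assay (on this read-out higher numbers stand for weaker inhibition of growth and lower numbers for stronger inhibition of growth), three compounds built on one shared core have been measured. Compound 1 `CC1=CC[C@@H]([C@@](C)(O)CCCC(C)(C)NC(=S)NN)CC1` gives > 100000 nM, which is a limit of the assay and not a number. Compound 2 `CC1=CC[C@@H]([C@@](C)(O)CCCC(C)(C)NC(=S)N/N=C\c2ccc(C)cc2)CC1` gives 11800 nM, and compound 3 `COc1ccc(/C=N\NC(=S)NC(C)(C)CCC[C@](C)(O)[C@@H]2CC=C(C)CC2)cc1` gives 15800 nM. For the measured compounds named here, compound 3 therefore stands within the scatter of compound 2, and these are the only two measured compounds with a number rather than a limit. The steps that bring in the aromatic ring are large: an at least 8.4-fold lower number from compound 1 to compound 2 (0.92 log units; beyond the scatter), and an at least 6.3-fold lower number from compound 1 to compound 3 (0.80 log units; beyond the scatter). Compound 4 `CC1=CC[C@@H]([C@@](C)(O)CCCC(C)(C)NC(=S)N/N=C\c2ccc(N(C)C)cc2)CC1` keeps that ring and changes only its substituent: dimethylamino in place of methoxy on an aromatic carbon, para to a large group. The step that bears most directly on this change is the other exchange at the same place, a 1.3-fold higher number from compound 2 to compound 3 (0.13 log units; within the scatter). The two larger steps from compound 1 concern the whole aromatic group, so they say little about this exchange. Going by the values given here, with only one such step as a guide, the expected change is none beyond the scatter, and the estimated step is a 1.2-fold lower number from compound 3 to compound 4 (0.08 log units; within the scatter). For compound 4, the estimated value in this assay is 13000 nM, with an expected range from 5500 nM to 30000 nM.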

Compound 4, concentration for total growth inhibition: > 100000 nM
Compound 4 was reported as a limit; the forecaster's own chance of this, stated with the estimate: 5%; at least 7.6-fold (0.88 log units) between middle value and limit.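

Up to this point, the only exchange at this place on the ring in this assay was methoxy for methyl, and it stayed within the scatter, with a 1.3-fold higher number from compound 2 to compound 3 (0.13 log units; within the scatter). Compound 4 shows that this position is not indifferent to its substituent. The 4-methoxyphenyl to 4-(dimethylamino)phenyl change gives an at least 6.3-fold higher number from compound 3 to compound 4 (0.80 log units; beyond the scatter), and the comparison with the methyl compound gives an at least 8.4-fold higher number from compound 2 to compound 4 (0.92 log units; beyond the scatter), both beyond the scatter. Compound 4 gives > 100000 nM, which is a limit of the assay and not a number, so both steps give only a minimum size, and this limit recurs among the compounds shown: the limit of > 100000 nM in this assay, at which 2 of the 4 values shown sit.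

Whether the result follows the nitrogen atom of dimethylamino or the whole group stays open, as none of the compounds shown carries a plain amino group, a methylamino group or an isopropyl group at this place. Going by these compounds, whether a carboxylic acid or a chlorine atom there would sit with compound 2 and compound 3 or with compound 4 is equally open.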